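Benzyl versus pyridin-2-ylmethyl amides in a cytotoxicity series

This account rests on a few compounds, and the source may have more. Where it says the series, first, only, none or still open, it means among the compounds named here.

Measured compounds:
compound 1 `N[C@H]1CC[C@H](Nc2c(C(=O)NCc3ccccn3)nc(Br)c3cccnc23)CC1` — "not determined" (no result reported)
compound 2 `NCCCNc1c(C(=O)NCc2ccc(F)cc2)ncc2cccnc12` — > 10000 nM
compound 3 `O=C(NCCCNc1c(C(=O)NCc2ccc(F)cc2)nc(Br)c2cccnc12)c1ccccc1` — 1000 nM

For the measured compounds named here, in a functional assay on SK-BR-3 cells (Homo sapiens) for cytotoxicity, read by MTT assay, with a stated time of 72 h (a higher number here means a weaker inhibitor, a lower number a stronger inhibitor), compound 3 gives 1000 nM, the only plain number in the set. For compound 2 the result is a limit of the assay, > 10000 nM, not a number. Compound 1 has no single number here; its entry reads "not determined" (no result reported). Of the values shown, one sits at the limit of > 10000 nM in this assay, at which 1 of the 3 values shown sits. Compound 1 therefore stands nowhere on the scale yet, and the comparison to compound 4 `N[C@H]1CC[C@H](Nc2c(C(=O)NCc3ccccc3)nc(Br)c3cccnc23)CC1` rests on the structural change alone.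

Compound 4 differs from compound 1 in one place: phenyl in place of pyridin-2-yl on a saturated chain carbon bound to an amide-type nitrogen. Going by the values given here, no step between measured compounds carries this change, so nothing in the set fixes its size. The expectation for this assay is a step no larger than the scatter, in no settled direction. On that basis compound 4 is estimated at 1000 nM in this assay, within 200 nM to 5000 nM.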

Compound 4, half-maximal inhibitory concentration: 8000 nM
For compound 4 the middle estimate is 8.0-fold (0.90 log units) below the measured one, outside the stated range (above it).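

No step can be read between compound 1 and compound 4 in this assay, as compound 1 has no single number there. The compounds shown leave open the size and direction of the change from pyridin-2-yl to phenyl on the shared core in this assay.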